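A few compounds are considered here, and "the series" means these few. Any claim that something is new, unique, unknown or untested is made for them only; others in the source may bear on it.

Compounds measured so far:
compound 1 `Cc1cc(C)c(-c2csc(NC(=O)/C=C/c3ccc(F)cc3)n2)c(C)c1` — 14000 nM
compound 2 `Cc1cc(C)c(-c2csc(NC(=O)/C=C/c3ccc(Br)cc3)n2)c(C)c1` — 4590 nM
compound 3 `Cc1cc(C)c(-c2csc(NC(=O)/C=C/c3ccc(N4CCCCC4)cc3)n2)c(C)c1` — 4060 nM

In a functional assay on K562 cells (Homo sapiens) for inhibition, read by MTT assay, with a stated time of 96 h (on this read-out higher numbers stand for weaker inhibition and lower numbers for stronger inhibition), compound 2 stands second highest of the three numbers. Its nearest neighbour is compound 3, and that gap a 1.1-fold lower number from compound 2 to compound 3 (0.05 log units; within the scatter) lies within the scatter; the furthest is compound 1, the step of a 3.1-fold lower number from compound 1 to compound 2 (0.48 log units; beyond the scatter) being a modest one beyond the scatter. The unmeasured compound 4 `Cc1cc(C)c(-c2csc(NC(=O)/C=C/c3ccncc3)n2)c(C)c1` differs from compound 2 in one place: pyridin-4-yl in place of 4-bromophenyl on a double-bonded chain carbon bound to a double-bonded chain carbon. The steps that bear on it are those at the same end of the chain, a 3.1-fold lower number from compound 1 to compound 2 (0.48 log units; beyond the scatter) and a 3.4-fold lower number from compound 1 to compound 3 (0.54 log units; beyond the scatter), both modest and both toward lower numbers; no measured step swaps the whole six-membered ring for another, so the change to compound 4 is not covered directly by any pair shown. Since the two groups that gave the lower numbers are the larger ones and the ring entering in compound 4 is the smallest group tried here, the writer expects compound 4 to drift toward the higher numbers in this assay, with a step of a 2.0-fold higher number from compound 2 to compound 4 (0.29 log units; within the scatter) that may well stay within the scatter. The estimate for compound 4 is 9000 nM, with a range from 3000 nM to 30000 nM.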

Compound 4, half-maximal inhibitory concentration: 9390 nM
For compound 4 the middle estimate is 1.0-fold (0.02 log units) below the measured one, and the stated range covers the measured number.
By their numbers in this assay, from the lowest: compounds 3 and 2 (each within the scatter of the next); then compounds 4 and 1 (each within the scatter of the next).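

In this assay, putting pyridin-4-yl in place of 4-bromophenyl on a double-bonded chain carbon bound to a double-bonded chain carbon is the first change shown that replaces the whole ring, and it has a measurable if modest effect: a 2.0-fold higher number from compound 2 to compound 4 (0.31 log units; beyond the scatter) lies beyond the scatter. Set against the 4-fluorophenyl group, the same ring cannot be told apart, since a 1.5-fold lower number from compound 1 to compound 4 (0.17 log units; within the scatter) lies within the scatter, so at this place a ring with a hetero atom reads level with compound 1 while standing apart from compound 2. No measurement accompanies these compounds that would speak to what lies behind either step.

The compounds shown leave open how an unsubstituted phenyl ring would read, and that single group would separate the loss of the bromine from the entry of the ring nitrogen. They also leave open whether pyridin-3-yl or pyridin-2-yl would read like pyridin-4-yl, and how a pyridin-4-yl ring bearing a piperidin-1-yl group would compare with compound 3.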